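Methoxy to Hydroxy: One Small Change on a Growth Inhibitor

The source may report more compounds than this note shows. Statements on the series, on what has been measured and on what is new or still open speak of the compounds shown alone.

Of the compounds shown here, two sharing the same core have been tested for their ability to slow the growth of a cancer cell line. Compound 1 `COc1cc(C)cc(-c2c(-c3ccnc(-c4ccc(N(C)C)cc4)c3)cnn2CC#N)c1` returns only a limit in a functional assay on OVCAR-5 cells (Homo sapiens) for inhibition, read by sulforhodamine B assay, with a stated time of 48 h (on this read-out lower numbers stand for stronger inhibition of growth and higher numbers for weaker inhibition of growth), namely > 100000 nM, so no number is known for it. For the measured compounds named here, compound 2 `COc1cc(C)cc(-c2nn(CC#N)cc2-c2ccnc(-c3ccc(N(C)C)cc3)c2)c1` is the one compound with an actual number: in this assay compound 2 gives 3980 nM. Going by the values given here, with one value and one limit, there is no measured step between compounds to learn from, and compound 2 simply stands as the only fixed point.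

Compound 3 `Cc1cc(O)cc(-c2nn(CC#N)cc2-c2ccnc(-c3ccc(N(C)C)cc3)c2)c1` has not yet been measured. Its difference from compound 2 is hydrogen in place of methyl on an oxygen on an aromatic ring, that is, a methoxy group becoming a hydroxy group on the 3-methoxy-5-methylphenyl ring. Without any measured step that shows what this kind of change does in this series, the expected step of a 1.0-fold higher number from compound 2 to compound 3 (0.00 log units; within the scatter) is small, in either direction, and likely within the usual scatter. Compound 3 is therefore estimated at 4000 nM in this assay, with a range from 1500 nM to 12000 nM.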

Compound 3, concentration for 50% growth inhibition: 1490 nM
Compound 3: middle estimate off by 2.7-fold (0.43 log units), on the high side, outside the stated range (below it).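

The change from methoxy to hydroxy gives a 2.7-fold lower number from compound 2 to compound 3 (0.43 log units; beyond the scatter) in this assay, a modest step, but the first measured one in this series. It shows that the oxygen on the 3-methoxy-5-methylphenyl ring is a place where a very small edit, the loss of one methyl group, can shift the result, and that here the shift is towards stronger inhibition of growth. Nothing in the data shown accounts for the direction or the size of this step.

One step cannot show whether the shift comes from gaining the hydroxy group or from losing the methyl, and an amine in place of the hydroxy group, or an ethoxy group in place of the methoxy group, would help to tell how much this position tolerates. From the compounds shown here alone, it also remains open whether the same change would do anything for compound 1, which carries the same methoxy group and whose result of > 100000 nM is only a limit.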